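Changing the phenyl group of compound 3

This account rests on a few compounds, and the source may have more. Where it says the series, first, only, none or still open, it means among the compounds named here.

Measured in a functional assay on MDA-MB-231 cells (Homo sapiens) for antiproliferative activity, read by MTT assay, with a stated time of 72 h; a higher number here means a weaker inhibitor, a lower number a stronger inhibitor:
Compound 1 `O=C(CCc1cccc2c1B(O)OC2)Nc1ccccc1`: 230 nM
Compound 2 `CC(C)c1cccc(NC(=O)CCc2cccc3c2B(O)OC3)c1`: 1600 nM
Compound 3 `COc1ccc(-c2cccc(NC(=O)CCc3cccc4c3B(O)OC4)c2)cc1`: 88 nM

Compound 3 holds the lowest number of the three, and both of the others lie beyond the scatter from it. Compound 4 `CSc1cccc(-c2cccc(NC(=O)CCc3cccc4c3B(O)OC4)c2)c1` keeps the shared core and differs in one group: 3-(methylsulfanyl)phenyl in place of 4-methoxyphenyl on an aromatic carbon. It carries 3-(methylsulfanyl)phenyl in place of 4-methoxyphenyl on an aromatic carbon, meta to a large group.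

Going by the values given here, three measured steps bear on this place. The 4-methoxyphenyl group gave a 2.6-fold lower number from compound 1 to compound 3 (0.42 log units; beyond the scatter), isopropyl gave a 7.0-fold higher number from compound 1 to compound 2 (0.84 log units; beyond the scatter), and exchanging isopropyl for 4-methoxyphenyl gave an 18-fold lower number from compound 2 to compound 3 (1.26 log units; beyond the scatter). The largest of these separates a phenyl group from an isopropyl group. No measured step compares one substituted phenyl group with another, so the size of this change is not shown directly. Since a substituted phenyl group stays in place, the expectation is no step beyond the scatter in this assay, in either direction, with compound 3 at 88 nM as the anchor.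

The expected step is a 1.1-fold higher number from compound 3 to compound 4 (0.06 log units; within the scatter).

For compound 4 the estimated value is 100 nM, with an expected range of 30 nM to 330 nM.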

Compound 4, half-maximal inhibitory concentration: 150 nM
Estimate against measurement, compound 4: 1.5-fold (0.18 log units) below; the measured number falls inside the stated range.
By their numbers in this assay, from the lowest: compounds 3, 4 and 1 (each within the scatter of the next, the first and the last beyond it); then compound 2.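

In this assay, going by these compounds alone, the exchange gave a 1.7-fold higher number from compound 3 to compound 4 (0.23 log units; within the scatter), the first measured comparison of one substituted phenyl group with another at this place, and it shows that 3-(methylsulfanyl)phenyl can take the place of 4-methoxyphenyl without a difference the assay can resolve. The two phenyl groups stand alike against isopropyl, since 3-(methylsulfanyl)phenyl gave an 11-fold lower number from compound 2 to compound 4 (1.03 log units; beyond the scatter), so the large separation seen earlier with compound 3 is not confined to 4-methoxyphenyl, but the gain over hydrogen is less secure, as 3-(methylsulfanyl)phenyl gave only a 1.5-fold lower number from compound 1 to compound 4 (0.19 log units; within the scatter), whereas the step from compound 1 to compound 3 lay beyond the scatter. No accompanying measurement offers an explanation for any of these numbers.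

This exchange puts sulfur in place of oxygen and also moves the substituent on the phenyl ring, and the compounds shown do not separate these two changes. Going by these compounds, it also remains open whether a phenyl group carrying an amine or a carboxylic acid at this place would stay close to compound 3 in this assay, or would fall back towards compound 2.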